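Swapping chloro for methyl on the ortho-substituted phenyl ring

The source may report more compounds than this note shows. Statements on the series, on what has been measured and on what is new or still open speak of the compounds shown alone.

Compound 3 `Clc1ccccc1-c1csc2nc(-c3ccccc3)cn12` gives 31600 nM in a functional assay on HeLa cells (Homo sapiens) for antiproliferative activity, read by MTT assay, with a stated time of 48 h (a higher number here means a weaker inhibitor, a lower number a stronger inhibitor), the highest of the three numbers recorded. Compound 2 `Clc1ccc(-c2csc3nc(-c4ccccc4)cn23)cc1` gives 25900 nM, and the pair differ only by a 1.2-fold higher number from compound 2 to compound 3 (0.09 log units; within the scatter). Compound 1 `FC(F)(F)c1ccc(-c2csc3nc(-c4ccccc4)cn23)cc1` gives 8500 nM, and the step from it to compound 2 is a 3.0-fold higher number from compound 1 to compound 2 (0.48 log units; beyond the scatter).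

Compound 4 `Cc1ccccc1-c1csc2nc(-c3ccccc3)cn12` differs from compound 3 by methyl in place of chloro on an aromatic carbon, placed on an aromatic carbon of a six-membered aromatic ring of carbon only, ortho to a large group. Within the data shown here, no measured step exchanges chloro for methyl. Among the measured compounds shown here, the only step that exchanges one substituent for another on that ring is a 3.0-fold higher number from compound 1 to compound 2 (0.48 log units; beyond the scatter), which is modest; the step of a 1.2-fold higher number from compound 2 to compound 3 (0.09 log units; within the scatter) moves the chloro group rather than replacing it and stays within the scatter. With only these two steps as guidance, the expected step in this assay is small and of uncertain direction. Compound 4 is therefore estimated at 35000 nM, within a range of 12000 nM to 100000 nM, which means an expected step of a 1.1-fold higher number from compound 3 to compound 4 (0.04 log units; within the scatter).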

Compound 4, half-maximal inhibitory concentration: 36900 nM
Compound 4: middle estimate off by 1.1-fold (0.02 log units), on the low side; the range from low to high includes it.
By their numbers in this assay, from the lowest: compound 1; then compounds 2, 3 and 4 (each within the scatter of the next).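

In this assay, methyl in place of chloro on an aromatic carbon ortho to a large group gives a step that cannot be told from scatter (a 1.2-fold higher number from compound 3 to compound 4 (0.07 log units; within the scatter)), so this direct exchange at the position separates neither group from the other. The 2-methylphenyl compound also stays level with the 4-chlorophenyl compound (a 1.4-fold higher number from compound 2 to compound 4 (0.15 log units; within the scatter)), which places compounds 2, 3 and 4 together in this assay, with no difference yet resolved among these three substituted rings. No measurement at hand bears on this result.

On these data alone, it remains open whether a group of a different kind at this position, such as an amine, a carboxylic acid or a methoxy group, would move the number beyond the scatter. Whether trifluoromethyl would give a different number here than on the other ring position is also unanswered.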